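From trifluoromethyl to dimethoxy in a growth-inhibiting series

A few compounds are considered here, and "the series" means these few. Any claim that something is new, unique, unknown or untested is made for them only; others in the source may bear on it.

Measured in a functional assay on HOP-62 cells (Homo sapiens) for inhibition, read by sulforhodamine B assay; on this read-out higher numbers stand for weaker inhibition of growth and lower numbers for stronger inhibition of growth:
Compound 1 `Cc1ccc2[nH]c(-c3ccc(-c4ccc(-c5ccc(N(C)C)cc5)cc4)cc3)nc2c1` gives 4230 nM
Compound 2 `Cc1ccc2[nH]c(-c3ccc(-c4ccc(-c5cccc(Cl)c5)cc4)cc3)nc2c1` gives 2740 nM
Compound 3 `FC(F)(F)c1ccc(-c2ccc(-c3ccc(-c4nc5ccccc5[nH]4)cc3)cc2)cc1` gives 100000 nM

Compound 3 stands at the top of these numbers. Its value is the highest of the three and lies beyond the scatter from both compound 1 and compound 2. Among the measured compounds shown here, its core differs from that of compounds 1 and 2, and no measured pair separates that difference from the change of phenyl group.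

Compound 4 `COc1ccc(-c2ccc(-c3ccc(-c4nc5ccccc5[nH]4)cc3)cc2)cc1OC` keeps the core of compound 3 and carries 3,4-dimethoxyphenyl in place of 4-(trifluoromethyl)phenyl on an aromatic carbon. For the measured compounds named here, one measured step bears on this, the exchange of 4-(dimethylamino)phenyl for 3-chlorophenyl: a 1.5-fold lower number from compound 1 to compound 2 (0.19 log units; within the scatter). Going by the values given here, that exchange of one substituted phenyl for another stayed within the scatter, and it is the only guide available. Compound 3 nevertheless sits far above compound 2 at 2740 nM. A moderate move to a lower number is therefore expected in this assay, with wide uncertainty. The estimated change is a 5.0-fold lower number from compound 3 to compound 4 (0.70 log units; beyond the scatter). For compound 4 the estimated value is 20000 nM, with an expected range of 3000 nM to 100000 nM.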

Compound 4, concentration for 50% growth inhibition: 4200 nM
The estimate for compound 4 lay 4.8-fold (0.68 log units) above the measured number; the range from low to high includes it.
By their numbers in this assay, from the lowest: compounds 2, 4 and 1 (each within the scatter of the next); then compound 3.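

In this assay, among the compounds shown here, with the core of compound 3 held fixed, the exchange of 4-(trifluoromethyl)phenyl for 3,4-dimethoxyphenyl gives a 24-fold lower number from compound 3 to compound 4 (1.38 log units; beyond the scatter) and so is a large step beyond the scatter, whereas the only earlier step between substituted phenyl groups, a 1.5-fold lower number from compound 1 to compound 2 (0.19 log units; within the scatter) on another core, stayed within it. This shows that a change of the phenyl group alone, on an aromatic carbon para to a large group, can shift this read-out strongly, so the very high number of compound 3 is not a matter of its core alone. No measurement shown here explains why this exchange matters so much, and the counts of atoms and hydrogen-bond acceptors describe the change without accounting for it.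

Going by these compounds, it remains open whether the step follows from losing the trifluoromethyl group or from gaining the methoxy groups, and a single 4-methoxyphenyl, 3-methoxyphenyl or 4-hydroxyphenyl group on the same core would help to separate these. Also open, on these data alone, is whether 3,4-dimethoxyphenyl and 4-(trifluoromethyl)phenyl would differ as widely on the core of compounds 1 and 2, which carries a methyl group.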